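The source may report more compounds than this note shows. Statements on the series, on what has been measured and on what is new or still open speak of the compounds shown alone.

Measured so far:
compound 1, `OC(c1ccccn1)C1(c2ccc(Cl)c(Cl)c2)CCOC1`: 630 nM
compound 2, `OC(c1ccc(F)cn1)C1(c2ccc(Cl)c(Cl)c2)CCC1`: 910 nM

In an assay on HEK293 cells for antagonist activity at transient receptor potential cation channel subfamily V member 3 (Homo sapiens), read by FLIPR and calcium flux (on this read-out lower numbers stand for stronger inhibition and higher numbers for weaker inhibition), compound 1 gives 630 nM and compound 2 gives 910 nM. The two values fall within the scatter of repeated measurements, so compound 2 stands level with compound 1 on the numbers shown; the two differ in more than one place, so nothing is read into the gap between them.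

Compound 3, `OC(c1ncccc1F)C1(c2ccc(Cl)c(Cl)c2)CCC1`, is not yet measured. It differs from compound 2 as follows: 3-fluoropyridin-2-yl in place of 5-fluoropyridin-2-yl on a saturated chain carbon bound to an oxygen on a saturated carbon and a saturated ring carbon. Within the data shown here, no measured pair shows this change, so no step of known size can be carried over.

In this assay the change is expected to give no step beyond the scatter; the step from compound 2 to compound 3 is estimated at a 1.1-fold higher number from compound 2 to compound 3 (0.04 log units; within the scatter). Compound 3 is expected to give 1000 nM, with a range from 400 nM to 2500 nM.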

Compound 3, antagonist equilibrium constant: 610 nM
Estimate against measurement, compound 3: 1.6-fold (0.21 log units) above, and the stated range covers the measured number.
By their numbers in this assay, from the lowest: compounds 3, 1 and 2 (each within the scatter of the next).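

In this assay, among these compounds, 3-fluoropyridin-2-yl in place of 5-fluoropyridin-2-yl gives a 1.5-fold lower number from compound 2 to compound 3 (0.17 log units; within the scatter), the first step that can be read in one place. On this read-out, the two fluoropyridinyl groups therefore stand level on the saturated chain carbon bound to an oxygen, and this one change of fluorine placement gives no step beyond the scatter. No supporting measurement bears on this result, and no explanation can be offered for it.

Open, as far as these compounds go, is whether a different group on the same pyridine ring, such as a methoxy group, a nitrile or an amine, would give a step beyond the scatter. Also open, from the compounds shown here alone, is whether the hydroxyl group on the chain carbon can be exchanged for an amine with the rest of compound 3 held fixed.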